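A few compounds are considered here, and "the series" means these few. Any claim that something is new, unique, unknown or untested is made for them only; others in the source may bear on it.

Values in an ADME assay on Vero cells (Chlorocebus sabaeus) for cytotoxicity; on this read-out higher numbers stand for weaker inhibition and lower numbers for stronger inhibition:
- Compound 1 `C=C/C=C\[C@H](C)[C@H](OC(N)=O)[C@@H](C)[C@H](O)[C@@H](C)C/C(C)=C\[C@H](C)[C@@H](O)[C@@H](C)/C=C\[C@@H](O)C[C@@H]1OC(=O)[C@H](C)[C@@H](O[Si](C)(C)C(C)(C)C)[C@H]1C`: 420 nM
- Compound 2 `C=C/C=C\[C@H](C)[C@H](OC(N)=O)[C@@H](C)[C@H](O)[C@@H](C)CC(=C)[C@H]1[C@H](C)[C@@H](O)[C@@H](C)[C@@H]1/C=C/C[C@@H]1OC(=O)[C@H](C)[C@@H](O)[C@H]1C`: 690 nM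
- Compound 3 `C=C/C=C\[C@H](C)[C@H](OC(N)=O)[C@@H](C)[C@H](O)[C@@H](C)C[C@@](C)(O)[C@H]1[C@H](C)[C@@H](O)[C@@H](C)[C@@H]1/C=C/C[C@@H]1OC(=O)[C@H](C)[C@@H](O)[C@H]1C`: 4300 nM

Compound 3 has the highest number of the three, and its gaps to compound 2 and to compound 1 both lie beyond the scatter. Compound 4 `C=C/C=C\[C@H](C)[C@H](OC(N)=O)[C@@H](C)[C@H](O)[C@@H](C)C[C@](C)(O)[C@H]1[C@H](C)[C@@H](O)[C@@H](C)[C@@H]1/C=C/C[C@@H]1OC(=O)[C@H](C)[C@@H](O)[C@H]1C` is the next point: the two compounds have the same atoms and bonds and differ only in configuration as drawn: 1 of 17 stereo elements differ; a stereocentre at a saturated chain carbon is drawn R in compound 3 and S in compound 4. For the measured compounds named here, no measured pair isolates a change of this kind, so the data offer no direct guide to its size. On these data alone, with the atoms and bonds unchanged, no step beyond the scatter is expected in this assay, though either direction remains open. The estimated 1.3-fold lower number from compound 3 to compound 4 (0.11 log units; within the scatter) is small. For compound 4 the expected value is 3300 nM, with an estimated range of 1200 nM to 9000 nM.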

Compound 4, half-maximal inhibitory concentration: 16600 nM
Beside the measured number, compound 4's estimate is 5.0-fold (0.70 log units) below it; measured number outside the range, above it.
By their numbers in this assay, from the lowest: compounds 1 and 2 (each within the scatter of the next); then compound 3; then compound 4.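

In this assay, configuration alone at this saturated chain carbon shifts the number, with a 3.9-fold higher number from compound 3 to compound 4 (0.59 log units; beyond the scatter). For the compounds shown here, no earlier pair isolated such a change, and here the S drawing goes with the weaker inhibition, so this stereocentre is not silent on this read-out. The step can be assigned to this one stereocentre, with nothing entering or leaving: the fact that compounds 3 and 4 differ only in the configuration as drawn

Still open, on these data alone, is whether the gap between the R and S drawings persists with an amine at this carbon. As far as these compounds go, whether it holds in a compound carrying a longer chain is equally open.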